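The compounds below may be only part of what the source reports. "The series", "measured", "known", "first", "only" and "open" are said of these compounds alone.

Compound 1 `COc1cc(C(=O)c2ccc3nc(/C=C/C(=O)NO)ccc3c2)cc(OC)c1OC`: 3350 nM
Compound 2 `COc1cccc(Oc2ccc3nc(/C=C/C(=O)NO)ccc3c2)c1`: 4350 nM

In a functional assay on A549 cells (Homo sapiens) for antiproliferative activity, read by sulforhodamine B assay, with a stated time of 48 h (a lower number here means a stronger inhibitor of growth, a higher number a weaker inhibitor of growth), compound 2 gives 4350 nM. This lies within the scatter of compound 1 at 3350 nM, so the two numbers cannot be told apart. The next compound to be tested is compound 3 `COc1ccc(Oc2ccc3nc(/C=C/C(=O)NO)ccc3c2)cc1`, which has the same atoms as compound 2, joined differently: 4-methoxyphenyl in place of 3-methoxyphenyl on an oxygen on an aromatic ring. The 4-methoxyphenyl takes the place of the 3-methoxyphenyl on an oxygen on an aromatic ring, and everything else stays the same. For the measured compounds named here, no measured step between closely matched compounds is available as a guide, so no direction can be favoured, and no step beyond the scatter is expected in this assay. The expected change is a 1.1-fold lower number from compound 2 to compound 3 (0.04 log units; within the scatter), an estimate anchored on compound 2 at 4350 nM. For compound 3 the estimated value is 4000 nM, with an expected range from 1500 nM to 10000 nM.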

Compound 3, concentration for 50% growth inhibition: 3200 nM
Compound 3: middle estimate off by 1.3-fold (0.10 log units), on the high side; the measured number falls inside the stated range.
By their numbers in this assay, from the lowest: compounds 3, 1 and 2 (each within the scatter of the next).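

In this assay, the 4-methoxyphenyl in place of the 3-methoxyphenyl on an oxygen on an aromatic ring gives a 1.4-fold lower number from compound 2 to compound 3 (0.13 log units; within the scatter), the first step available between closely matched compounds. This step lies within the scatter, so the assay does not tell these two groups apart at this position, and the change of joining leaves no readable difference in growth inhibition. No measured evidence bears on this result.

The two groups compared here are both methoxyphenyl groups, so the step says little about how far this position tolerates change. Going by these compounds, it remains open whether a group of another kind on that oxygen, such as a phenyl ring carrying an amine or a carboxylic acid, would give a step beyond the scatter.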